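Quinoxalinedione sulfonamides: oral exposure notes

This account rests on a few compounds, and the source may have more. Where it says the series, first, only, none or still open, it means among the compounds named here.

Measured compounds:
- compound 1 `Cc1cc2[nH]c(=O)c(=O)[nH]c2c(N(CC(=O)O)S(C)(=O)=O)c1Cl`: 155 ng.h/mL
- compound 2 `Cc1c(Cl)cc2[nH]c(=O)c(=O)[nH]c2c1N(CC(=O)O)S(C)(=O)=O`: 1500 ng.h/mL
- compound 3 `Cc1c(Cl)cc2[nH]c(=O)c(=O)[nH]c2c1N(CCO)S(C)(=O)=O`: 605 ng.h/mL

Three compounds have been run in an ADME assay on the whole organism (plasma, strain Sprague-Dawley) for pharmacokinetics, with Rattus norvegicus as the target, at a dose of 5 mg/kg by the oral route; a higher number here means more compound in the circulation at the dose given, a lower number less compound in the circulation. Compound 2 and compound 1 share the same atoms joined differently; the difference between the two cores is not broken down here. In this assay compound 2 gives 1500 ng.h/mL, while compound 1 gives 155 ng.h/mL, the lowest of the three numbers, and compound 3 gives 605 ng.h/mL.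

For the measured compounds named here, the one matched step so far is hydroxymethyl in place of carboxy on a saturated chain carbon bound to a sulfonamide nitrogen, which produced a 2.5-fold lower number from compound 2 to compound 3 (0.39 log units; beyond the scatter).

Compound 4 `Cc1cc2[nH]c(=O)c(=O)[nH]c2c(N(CCO)S(C)(=O)=O)c1Cl` has not yet been run in this assay. It carries the same change on the core of compound 1: hydroxymethyl in place of carboxy on a saturated chain carbon bound to a sulfonamide nitrogen. This change has been seen only once among the compounds here, and only on the core of compound 2, so its transfer to the core of compound 1 is not established by a second example. Going by the values given here, the working expectation is that compound 4 behaves like compound 3 relative to its parent, with an estimated step of a 2.5-fold lower number from compound 1 to compound 4 (0.40 log units; beyond the scatter) because a 2.5-fold lower number from compound 2 to compound 3 (0.39 log units; beyond the scatter) is the only precedent. Among the compounds with values here, on that basis the estimated value for compound 4 is 62 ng.h/mL, with an expected range from 25 ng.h/mL to 180 ng.h/mL, the range being wide since the single precedent rests on a different core.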

Compound 4, area under the concentration-time curve in the Rattus norvegicus assay: 791 ng.h/mL
Compound 4: the middle estimate sits 13-fold (1.11 log units) below what was measured, and the stated range ends below it.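

In the Rattus norvegicus assay compound 4 gives 791 ng.h/mL, and the same change on the core of compound 1 gives a 5.1-fold higher number from compound 1 to compound 4 (0.71 log units; beyond the scatter), so hydroxymethyl in place of carboxy on a saturated chain carbon bound to a sulfonamide nitrogen does not act alike on the two cores. Set side by side, the two steps differ in direction as well as in size, so the step measured on one core cannot be carried to the other in this series: the same change on two cores in the Rattus norvegicus assay, a 2.5-fold lower number (0.39 log units; beyond the scatter) from compound 2 to compound 3 and a 5.1-fold higher number (0.71 log units; beyond the scatter) from compound 1 to compound 4, 13-fold (1.10 log units) apart, beyond the scatter of two such steps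

With a single pair on each core, this shows that the outcome of the change depends on the core in these two cases, but it gives no reason for that and no rule for any further core. In a physicochemical assay for solubility (on this read-out lower numbers stand for lower solubility and higher numbers for higher solubility), compound 1 gives 72 ug/mL and compound 4 gives 70 ug/mL, a step of a 1.0-fold lower number from compound 1 to compound 4 (0.01 log units; within the scatter), which is only a reading on the core of compound 1, with nothing shown for the other core.

The compounds shown leave open how an amine or a primary amide in place of carboxy would read on each of the two cores in the Rattus norvegicus assay. On these data alone, a longer chain on the sulfonamide nitrogen, ending in either hydroxyl or carboxy, is equally open, as is whether the split between the cores would persist with it.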